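Aryl variation on a thiazole core and calcium-flux agonism

A few compounds are considered here, and "the series" means these few. Any claim that something is new, unique, unknown or untested is made for them only; others in the source may bear on it.

Compound 1, `Cc1nc(-c2cc3ccccc3o2)sc1COc1ccc2c(c1)OCC2CC(=O)O`, gives 14.8% in a functional assay on CHO cells for agonist activity at Free fatty acid receptor 1 (Homo sapiens), read by FLIPR and calcium flux, tested at 100 nM; a higher number here means a stronger effect of the compound at the concentration tested, a lower number a weaker effect.
Compound 2, `Cc1ccccc1-c1nc(C)c(COc2ccc3c(c2)OCC3CC(=O)O)s1`, gives 10.7% in this assay.
Compound 3, `Cc1nc(-c2cccc(Cl)c2)sc1COc1ccc2c(c1)OCC2CC(=O)O`, gives 43% in this assay.

Compound 3 stands highest of the three measured numbers: its step to the nearest, a number 28.2 percentage points higher from compound 1 to compound 3 (beyond the scatter), and to the furthest, a number 32.3 percentage points higher from compound 2 to compound 3 (beyond the scatter), both lie beyond the scatter, so on these numbers it is the most active of the set. Compounds 1 and 2 sit within the scatter of each other, a number 4.1 percentage points lower from compound 1 to compound 2 (within the scatter).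

Compound 4, `Cc1nc(-c2ccc(F)cc2)sc1COc1ccc2c(c1)OCC2CC(=O)O`, differs from compound 3 in one place: 4-fluorophenyl in place of 3-chlorophenyl on an aromatic carbon. The measured steps that bear on this are the two exchanges of the aryl group on the shared core, a number 28.2 percentage points higher from compound 1 to compound 3 (beyond the scatter) and a number 32.3 percentage points higher from compound 2 to compound 3 (beyond the scatter), each of which moved the read-out beyond the scatter in this assay. For the measured compounds named here, no measured step compares 4-fluorophenyl with 3-chlorophenyl, so the direction is uncertain. Since compound 3 is the highest number, an exchange of its aryl group is expected to give a downward step, a number 15 percentage points lower from compound 3 to compound 4 (beyond the scatter), though a value within the scatter of compound 3 is possible. Compound 4 is therefore estimated at 28% in this assay, with a range from 8% to 50%.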

Compound 4, a percentage reported as activity, at one concentration (the size of the read-out at that concentration, not a potency): 61.6%
For compound 4 the middle estimate is 33.6 percentage points below the measured one; measured number outside the range, above it.
By their numbers in this assay, from the lowest: compounds 2 and 1 (each within the scatter of the next); then compound 3; then compound 4.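

At the aromatic carbon of the five-membered aromatic ring with 1 nitrogen and 1 sulfur, 4-fluorophenyl in place of 3-chlorophenyl gives a further rise (a number 18.6 percentage points higher from compound 3 to compound 4 (beyond the scatter)) in this assay, so compound 3 did not mark the top of what this position can reach, even though the two groups have the same count of heavy atoms and the same carbon-only aromatic ring. For the compounds shown here, the same group also stands well clear of 2-methylphenyl (a number 50.9 percentage points higher from compound 2 to compound 4 (beyond the scatter)) and of 1-benzofuran-2-yl (a number 46.8 percentage points higher from compound 1 to compound 4 (beyond the scatter)), the largest steps seen at this position so far, and this makes compound 4 the most active of the four compounds. Nothing measured here accounts for this order among the aryl groups, which therefore stands as an observation only.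

As far as these compounds go, since the halogen and its place on the phenyl ring change together between compound 3 and compound 4, the effect of each alone stays open, and 4-chlorophenyl or 3-fluorophenyl at this position would be needed to separate them. From the compounds shown here alone, how a pyridine ring, or a phenyl ring carrying a methoxy group or a nitrile, would compare at this position also remains open.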